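Permeability notes on a triazine acylsulfonamide series

The source may hold more compounds than are shown below. What is called first, only, known or untested is meant among the compounds shown, and "the series" means these compounds.

Measured compounds:
compound 1 `CC(C)(C)NC(=O)NCCS(=O)(=O)NC(=O)c1ccc(Nc2nc(NC3(c4ccc(Cl)cc4)CC3)nc(OCC(F)(F)F)n2)cc1` — 49 nm/s
compound 2 `CC(=O)NCCS(=O)(=O)NC(=O)c1ccc(Nc2nc(NC3(c4ccc(Cl)cc4)CC3)nc(OCC(F)(F)F)n2)cc1` — 7 nm/s

For the measured compounds named here, in a physicochemical assay for permeability, using PAMPA, at pH 7.4 (on this read-out lower numbers stand for lower permeability and higher numbers for higher permeability), compound 2 sits at the lower of the two numbers; its nearest neighbour is compound 1, which lies higher by the single measured step, a 7.0-fold lower number from compound 1 to compound 2 (0.85 log units; beyond the scatter). That step is the only one in hand: it exchanges a tert-butylamino for a methyl on the carbonyl carbon and costs a modest amount of permeability.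

Compound 3 `CC(C)(C)CNCCS(=O)(=O)NC(=O)c1ccc(Nc2nc(NC3(c4ccc(Cl)cc4)CC3)nc(OCC(F)(F)F)n2)cc1` is not yet measured. It differs from compound 2 in one place: neopentyl in place of acetyl on an amine nitrogen. Going by the values given here, no measured pair reproduces this exchange; the step from compound 1 to compound 2 is the only guide, and it shows that removing a branched alkyl fragment at this end of the chain lowers the number, so putting a branched alkyl back, though on the nitrogen rather than the carbonyl, is read here as a possible partial recovery. On that basis compound 3 is expected to come out somewhat above compound 2 by a 2.1-fold higher number from compound 2 to compound 3 (0.33 log units; beyond the scatter), and the estimate for compound 3 in this assay is 15 nm/s, within 3 nm/s to 60 nm/s.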

Compound 3, apparent permeability: 651 nm/s
Estimate against measurement, compound 3: 43-fold (1.64 log units) below, outside the stated range (above it).
By their numbers in this assay, from the lowest: compound 2; then compound 1; then compound 3.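

In this assay, for the compounds shown here, the amine nitrogen at this end of the chain spans a far wider range than the earlier compounds showed: a 93-fold higher number from compound 2 to compound 3 (1.97 log units; beyond the scatter), neopentyl in place of acetyl, is a large step, whereas the only earlier step, a 7.0-fold lower number from compound 1 to compound 2 (0.85 log units; beyond the scatter), was modest. The step of a 13-fold higher number from compound 1 to compound 3 (1.12 log units; beyond the scatter), neopentyl in place of (tert-butyl)carbamoyl, is also large, so compound 3 stands above both compounds that have a carbonyl on this nitrogen, and a branched alkyl group alone does not account for the result, as compound 1 also carries a tert-butyl group. No measurement in hand explains the size of these steps.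

The compounds shown do not separate the loss of the carbonyl on this nitrogen from the arrival of the neopentyl group; a straight pentyl chain or a small ethyl group on the same nitrogen, and a neopentyl group joined through a carbonyl, would bear on that. Also open, going by these compounds, is how a tertiary amine, with a methyl group added to this nitrogen in compound 3, or a carboxylic acid at the end of the chain would read in this assay.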